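Swapping the Benzylamine Aryl Group on a Dopamine Transporter Ligand

The source may hold more compounds than are shown below. What is called first, only, known or untested is meant among the compounds shown, and "the series" means these compounds.

Of the compounds shown here, three built on one shared core have been measured in an assay on striatum for inhibition of sodium-dependent dopamine transporter (Rattus norvegicus); on this read-out lower numbers stand for stronger inhibition and higher numbers for weaker inhibition. Compound 2 `Oc1ccc(CN[C@@H]2CO[C@H](C(c3ccc(F)cc3)c3ccc(F)cc3)C[C@H]2O)cc1F` gives 13.1 nM in this assay, the lowest of the three numbers. Compound 1 `COc1ccc(CN[C@@H]2CO[C@H](C(c3ccccc3)c3ccccc3)C[C@H]2O)cn1` gives 44.1 nM, a number that lies beyond the scatter above that of compound 2. Compound 3 `c1ccc(C(c2ccccc2)[C@@H]2CC[C@H](NCc3ccc4occc4c3)CO2)cc1` gives 81.9 nM, the highest of the three and the furthest from compound 2, again beyond the scatter.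

Compound 4 `COc1ccc(CN[C@@H]2CO[C@H](C(c3ccc(F)cc3)c3ccc(F)cc3)C[C@H]2O)cn1` has not yet been measured. It differs from compound 2 in a single place: 6-methoxypyridin-3-yl in place of 3-fluoro-4-hydroxyphenyl on a saturated chain carbon bound to an amine nitrogen. Among the measured compounds shown here, no measured pair shows exactly this change on its own. Compound 1 carries the same 6-methoxypyridin-3-yl group on the same chain carbon but also differs elsewhere from compound 2, so the value of compound 1, 44.1 nM, only hints at the direction. The step is expected to be modest and toward a weaker number, close to the edge of the scatter, a 1.9-fold higher number from compound 2 to compound 4 (0.28 log units; within the scatter). Compound 4 is therefore estimated to give 25 nM in this assay, expected to fall between 10 nM and 60 nM.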

Compound 4, inhibition constant: 20.1 nM
Estimate against measurement, compound 4: 1.2-fold (0.09 log units) above, and the stated range covers the measured number.
By their numbers in this assay, from the lowest: compounds 2 and 4 (each within the scatter of the next); then compounds 1 and 3 (each within the scatter of the next).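

In this assay, among the compounds shown here, putting 6-methoxypyridin-3-yl in place of 3-fluoro-4-hydroxyphenyl on a saturated chain carbon bound to an amine nitrogen gives a 1.5-fold higher number from compound 2 to compound 4 (0.19 log units; within the scatter) and thus the first reading of a change made at this position alone. The position therefore accepts an aromatic ring with 1 hetero atom and 0 hydrogen-bond donors in place of a carbon-only ring with 1 hydrogen-bond donor, with no difference that can be told from the scatter. No other measurement is at hand that could say why the two groups read alike.

On these data alone, the fluorine and the hydroxyl leave together in this change, so their separate shares remain open. Also open, as far as these compounds go, is how an aryl group carrying a carboxylic acid or a dimethylamino group would read here, or a longer chain leading to the amine nitrogen.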